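The source may report more compounds than this note shows. Statements on the series, on what has been measured and on what is new or still open speak of the compounds shown alone.

Working notes on the diaryl-pentyl urea series.

Compound 1 `O=C(NCCCCC(c1ccc(F)cc1)c1ccc(F)cc1)Nc1ccc(Cl)c(C(F)(F)F)c1` gives 3150 nM in a functional assay on MDA-MB-231 cells (Homo sapiens) for cytotoxicity, read by MTT assay, with a stated time of 48 h; on this read-out higher numbers stand for weaker inhibition and lower numbers for stronger inhibition. Compound 2 `Cc1ccc(NC(=O)NCCCCC(c2ccc(F)cc2)c2ccc(F)cc2)cc1C` carries the same chain but a different aryl urea terminus. For compound 2 this assay reports only a limit, > 20000 nM. The change between them is 3,4-dimethylphenyl in place of 4-chloro-3-(trifluoromethyl)phenyl on an amide-type nitrogen, and the step is an at least 6.3-fold higher number from compound 1 to compound 2 (0.80 log units; beyond the scatter); the size of that step rests on (the limit of > 20000 nM in this assay, at which 1 of the 3 values shown sits), so only its lower bound is known.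

Compound 3 `O=C(NCCCCN(c1ccc(F)cc1)c1ccc(F)cc1)Nc1ccc(Cl)c(C(F)(F)F)c1` gives 5040 nM in this assay. The two values of compound 1 and compound 3 lie within the usual scatter of each other; how their two cores differ is not broken down here.

Compound 4 `Cc1ccc(NC(=O)NCCCCN(c2ccc(F)cc2)c2ccc(F)cc2)cc1C` is not yet measured. Relative to compound 3 the change is 3,4-dimethylphenyl in place of 4-chloro-3-(trifluoromethyl)phenyl on an amide-type nitrogen, the same change as that made from compound 1 to compound 2, at the same place. The step from compound 3 to compound 4 is expected to be a 6.0-fold higher number from compound 3 to compound 4 (0.77 log units; beyond the scatter), resting on the earlier step of an at least 6.3-fold higher number from compound 1 to compound 2 (0.80 log units; beyond the scatter). Compound 4 is therefore estimated at 30000 nM, with a plausible range of 12000 nM to 80000 nM, and the assay is quite likely to report only a limit.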

Compound 4, half-maximal inhibitory concentration: > 20000 nM
Compound 4 was reported as a limit (the forecaster's own chance of this, stated with the estimate: 70%); the middle value is on the limit's open side.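

On the core of compound 3, 3,4-dimethylphenyl in place of 4-chloro-3-(trifluoromethyl)phenyl on an amide-type nitrogen gives an at least 3.9-fold higher number from compound 3 to compound 4 (0.59 log units; beyond the scatter) in this assay, and only the lower bound of this step is known. The direction of the change therefore carries over between the two cores, a statement that covers these two pairs only: the same change on two cores in this assay, an at least 6.3-fold higher number (0.80 log units; beyond the scatter) from compound 1 to compound 2 and an at least 3.9-fold higher number (0.59 log units; beyond the scatter) from compound 3 to compound 4; the limit leaves it open whether they differ

The true size of neither step can be read, so these data do not show that the two cores respond to the same extent, as compound 2 and compound 4 both end in the same limit: the limit of > 20000 nM in this assay, at which 2 of the 4 values shown sit.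

The compounds shown leave open which part of the 4-chloro-3-(trifluoromethyl)phenyl group matters, since no terminus here carries only the chlorine or only the trifluoromethyl group. Also open, as far as these compounds go, is whether the same change holds on either core with a longer chain, or with a terminal phenyl ring bearing an amine or a carboxylic acid.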